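This account rests on a few compounds, and the source may have more. Where it says the series, first, only, none or still open, it means among the compounds named here.

Measured compounds in an assay on membranes from Jurkat cells for displacement of a labelled ligand from Sigma intracellular receptor 2 (Homo sapiens), read by scintillation counting, with a stated time of 1 h; on this read-out lower numbers stand for stronger inhibition and higher numbers for weaker inhibition:

Compound 1 `CC(C)c1ccc(-c2nc(CN3CCCC3)nn2C)cc1` gives 1000 nM.
Compound 2 `Cn1nc(CN2CCCC2)nc1-c1ccc2ccsc2c1` gives > 1000 nM, a limit of the assay rather than a number.
Compound 3 `Cn1nc(CN2CCCC2)nc1-c1cccc(Oc2ccccc2)c1` gives > 1000 nM, also a limit of the assay.

Compound 1 thus holds the only number shown in this assay; the other two values are limits, as stated in the limit of > 1000 nM in this assay, at which 2 of the 3 values shown sit. For the measured compounds named here, with no pair of measured compounds differing in a single place, no measured step exists against which a new change can be set.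

Compound 4 `Cn1nc(CN2CCCC2)nc1-c1ccc(C(F)(F)F)cc1` is not yet measured. Relative to compound 1 the change is trifluoromethyl in place of isopropyl on an aromatic carbon, para to a large group. Going by the values given here, both the group that leaves and the group that enters are small, without donors, acceptors or charge, and the compounds around them give no measured step to lean on. The expected step is a 1.2-fold higher number from compound 1 to compound 4 (0.08 log units; within the scatter), none beyond the usual scatter. Compound 4 is therefore estimated at 1200 nM, within 400 nM to 3500 nM, with a real chance that the assay again reports only a limit.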

Compound 4, inhibition constant: > 1000 nM
Compound 4: only a limit was reported (the forecaster's own chance of this, stated with the estimate: 45%); the middle value does not contradict the limit.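

In this assay compound 4 gives > 1000 nM, a limit of the assay and not a number. The step from compound 1 to compound 4 therefore cannot be read in size; it shows only that trifluoromethyl in place of isopropyl, para to a large group, brings the number no lower. This is the first single-place change in the series, and its outcome adds to the values that give no number: the limit of > 1000 nM in this assay, at which 3 of the 4 values shown sit.

The measured step is a number no lower from compound 1 to compound 4 (the limit leaves the size open). From the compounds shown here alone, it remains open how large this step is, and whether any group at this position gives a number clearly lower than that of compound 1. An amine, a carboxylic acid or a longer chain on this aromatic carbon would bear on the second question only if it gave a number rather than a limit.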